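The source may report more compounds than this note shows. Statements on the series, on what has been measured and on what is new or still open speak of the compounds shown alone.

Compound 1 `O=S(=O)(Nc1ccc(-c2nc3ccccc3o2)cc1)c1cccs1` was tested in an assay on isolated protein for inhibition of malate dehydrogenase, mitochondrial (Sus scrofa), with stated times of 45 min and 30 min; a lower number here means a stronger inhibitor, a higher number a weaker inhibitor. There compound 1 gives > 63000 nM, which is a limit of the assay and not a number. Compound 2 `O=S(=O)(Nc1ccc2oc(-c3ccccc3)nc2c1)c1cccc(C(F)(F)F)c1` gives > 63000 nM, again a limit. Compound 3 `O=S(=O)(Nc1ccc2oc(-c3ccccc3)nc2c1)c1ccc(Cl)c(C(F)(F)F)c1` gives > 63000 nM, also a limit. Going by the values given here, the only change between measured compounds, a step that the two limits leave unreadable from compound 2 to compound 3, chloro in place of hydrogen on an aromatic carbon, therefore yields no readable size, and the limit of > 63000 nM in this assay, at which 3 of the 3 values shown sit, shows every value sitting at the same limit. Compound 4 `CCc1ccc(S(=O)(=O)Nc2ccc(-c3nc4ccccc4o3)cc2)cc1` differs from compound 1 by 4-ethylphenyl in place of thiophen-2-yl on a sulfonyl sulfur. Among the compounds with values here, no measured step bears on the exchange of the thiophen-2-yl for the 4-ethylphenyl, so nothing points to a move beyond the scatter. Compound 4 is accordingly expected to give about 100000 nM in this assay, between 30000 nM and 300000 nM. The expected step is a step that the limit leaves unreadable from compound 1 to compound 4.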

Compound 4, half-maximal inhibitory concentration: > 63000 nM
Compound 4 ended at the assay's limit (the forecaster's own chance of this, stated with the estimate: 80%); the middle value does not contradict the limit.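

Compound 1 and compound 4 both end at a limit and not at a number, so no step between them can be read: the limit of > 63000 nM in this assay, at which 4 of the 4 values shown sit.

The compounds shown leave open how strongly any of them inhibits in this assay, and whether the group on the sulfonyl sulfur matters at all.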